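A few compounds are considered here, and "the series" means these few. Any claim that something is new, unique, unknown or untested is made for them only; others in the source may bear on it.

Working notes on the series. Compound 1 `CCCn1c(=O)[nH]c2nc(-c3ccc(S(=O)(=O)N4CCN(Cc5cccc(C)c5)CC4)cc3)[nH]c2c1=O` is tested in an assay on CHO cells for displacement of a labelled ligand from adenosine receptor A3 (Homo sapiens), read by scintillation counting, with a stated time of 45 min, in the presence of a further agent that is not named here; a lower number here means a stronger inhibitor, a higher number a weaker inhibitor. In this assay compound 1 gives only a limit, > 1000 nM, not a number. Compound 2 `CCCn1c(=O)[nH]c2nc(-c3ccc(S(=O)(=O)N4CCN(c5cccc(Cl)c5)CC4)cc3)[nH]c2c1=O`, with 3-chlorophenyl in place of 3-methylbenzyl on the amine nitrogen in the ring, gives 53.5 nM, the step being an at least 18-fold lower number from compound 1 to compound 2 (1.27 log units; beyond the scatter). Compound 3 `CCCn1c(=O)[nH]c2nc(-c3ccc(S(=O)(=O)N4CCN(c5ccccc5Br)CC4)cc3)[nH]c2c1=O` again gives only a limit, > 1000 nM. The steps a step that the two limits leave unreadable from compound 1 to compound 3 and an at least 18-fold higher number from compound 2 to compound 3 (1.27 log units; beyond the scatter) read as they do because of the limit of > 1000 nM in this assay, at which 2 of the 3 values shown sit. Compound 4 `CCCn1c(=O)[nH]c2nc(-c3ccc(S(=O)(=O)N4CCN(Cc5ccc(Br)c(F)c5)CC4)cc3)[nH]c2c1=O` differs from compound 1 by 4-bromo-3-fluorophenyl in place of 3-methylphenyl on a saturated chain carbon bound to an amine nitrogen in a ring. Both readable steps swap the benzyl for a phenyl on the amine nitrogen, which compound 4 does not do, so neither bears directly on this change. Compound 4 is expected to remain near the limit, estimated at 2500 nM (range 700 nM to 10000 nM). The expected step is a step that the limit leaves unreadable from compound 1 to compound 4, within scatter.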

Compound 4, inhibition constant: > 1000 nM
Compound 4 gave a limit, no number (the forecaster's own chance of this, stated with the estimate: 70%); the middle value does not contradict the limit.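

In this assay compound 4 gives > 1000 nM, a limit and not a number, so a second benzyl group, now 4-bromo-3-fluorobenzyl, gives no readable value on the amine nitrogen in the ring. Among the compounds shown here, the one readable step is an at least 18-fold higher number from compound 2 to compound 4 (1.27 log units; beyond the scatter), with 4-bromo-3-fluorobenzyl in place of 3-chlorophenyl. The steps from compound 1 and from compound 3 to compound 4 cannot be read because both ends are limits: the limit of > 1000 nM in this assay, at which 3 of the 4 values shown sit.

Open, as far as these compounds go, is whether any benzyl group here gives a number in this assay. A 3-chlorobenzyl group would bear directly on this, as would a longer chain carrying the 3-chlorophenyl.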